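One Aryl Swap on the Carbonyl Carbon

The compounds below may be only part of what the source reports. "The series", "measured", "known", "first", "only" and "open" are said of these compounds alone.

Measured so far in a functional assay on KB cells (Homo sapiens) for cytotoxicity, read by MTT assay, with a stated time of 72 h; a lower number here means a stronger inhibitor, a higher number a weaker inhibitor:
compound 1 `COc1cc2ncnc(NNC(=S)NC(=O)c3ccc(F)cc3)c2cc1OC` gives 4530 nM;
compound 2 `Cc1ccc(C(=O)NC(=S)NNc2ncnc3ccccc23)cc1` gives 10100 nM;
compound 3 `O=C(NC(=S)NNc1ncnc2ccccc12)c1cccc(Cl)c1` gives 4740 nM.

Compound 3 stands second highest of these three numbers; its value and that of compound 1 lie within the scatter, while compound 2 sits clearly higher. Going by the values given here, the only step between measured compounds is a 2.1-fold lower number from compound 2 to compound 3 (0.33 log units; beyond the scatter), a change of the aryl group on the carbonyl carbon. Compound 4 `COc1ccccc1C(=O)NC(=S)NNc1ncnc2ccccc12` carries the same kind of change: 2-methoxyphenyl in place of 3-chlorophenyl on a carbonyl carbon. That one step shows such swaps shift this assay only modestly, so compound 4 is expected to land near compound 3, with a step of a 1.1-fold higher number from compound 3 to compound 4 (0.02 log units; within the scatter) that may stay within the scatter. The estimate for compound 4 is 5000 nM, within 2300 nM to 11000 nM.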

Compound 4, half-maximal inhibitory concentration: > 50000 nM
Compound 4 ended at the assay's limit; the forecaster's own chance of this, stated with the estimate: 5%; middle value at least 10-fold (1.00 log units) from the limit.
By their numbers in this assay, from the lowest: compounds 1 and 3 (each within the scatter of the next); then compound 2. At a limit, above all of these: compound 4.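

Swapping the aryl group on the carbonyl carbon can do far more than the earlier step suggested: 2-methoxyphenyl gives an at least 10-fold higher number from compound 3 to compound 4 (1.02 log units; beyond the scatter) and an at least 4.9-fold higher number from compound 2 to compound 4 (0.69 log units; beyond the scatter). So at this position, one aryl group in place of another can decide whether cytotoxicity is seen at all within the tested range. Compound 4 sits at a limit of the assay, not at a number: the limit of > 50000 nM in this assay, at which 1 of the 4 values shown sits.

The compounds shown do not separate the methoxy group itself from its place on the ring. Going by these compounds, how an amine or a carboxylic acid on that phenyl ring would read also stays open.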